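A few compounds are considered here, and "the series" means these few. Any claim that something is new, unique, unknown or untested is made for them only; others in the source may bear on it.

Measured compounds:
compound 1, `CC(=O)c1cc(CC(C)O)c(OCCCCC#N)cc1O`: in an assay on isolated protein for inhibition of leukotriene B4 receptor 1 (Homo sapiens), tested at 10 uM (on this read-out lower numbers stand for less inhibition and higher numbers for more inhibition at the one concentration tested (going by the name of the read-out)), compound 1 gives 10%
compound 2, `C=CCc1cc(C(C)=O)c(O)cc1OCC#N`: in this assay compound 2 gives 20%

Within the data shown here, compound 2 and compound 1 are the only two measured members, and their two numbers lie within the usual scatter of each other, so nothing separates compound 2 from compound 1 on what has been measured. Among the measured compounds shown here, no pair of measured compounds differs in one place, so there is no measured step to lean on for the change that follows.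

Compound 3, `C=CCc1cc(C(C)=O)c(O)cc1OCCCC`, remains to be measured in this assay. It differs from compound 2 in one place: propyl in place of cyano on a saturated chain carbon bound to an oxygen on an aromatic ring. For the measured compounds named here, both measured compounds carry a chain ending in a nitrile on the oxygen on the aromatic ring, and no measured compound carries a plain alkyl chain there, so the data give no direction for this change. The expected step from compound 2 to compound 3 in this assay is no change at the digits printed from compound 2 to compound 3 (within the scatter), that is none beyond the scatter, in either direction. Compound 3 is therefore estimated at 20%, with a range from 0% to 45%.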

Compound 3, a percentage reported as inhibition, at one concentration (the size of the read-out at that concentration, not a potency): 32%
Compound 3: middle estimate off by 12 percentage points, on the low side, within the range that was stated.
By their numbers in this assay, from the lowest: compounds 1 and 2 (each within the scatter of the next); then compound 3.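

In this assay, among these compounds, the change at this place, on a saturated chain carbon bound to an oxygen on an aromatic ring, gives a number 12 percentage points higher from compound 2 to compound 3 (beyond the scatter) and is the first step that can be read at all. The nitrile is therefore not required for the inhibition seen at this position, since the plain butoxy chain of compound 3 does at least as well as the cyanomethoxy chain of compound 2, although this rests on a single modest step from one pair, and compound 1 differs from both in more than one place and adds nothing to it. Nothing available on the compounds shown accounts for the step.

On these data alone, it remains open whether a longer chain than butyl, or a butyl chain ending in an amine or a carboxylic acid, would move the number further in either direction. As far as these compounds go, it is also open whether the same change from cyano to propyl gives a step of similar size on the core of compound 1, and all of these numbers are reads at one concentration rather than potencies.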